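Amide replacement on the shared core: compound 3 to compound 4

A few compounds are considered here, and "the series" means these few. Any claim that something is new, unique, unknown or untested is made for them only; others in the source may bear on it.

Three compounds share a core and differ only in the group on the aromatic carbon of the fused six-membered ring. Compound 1 `O=C(Nc1ccccc1)c1cnc(NCc2c(F)ccc3c2CCO3)n2cnnc12` carries a phenylcarbamoyl group and in an ADME assay on microsomes from liver (Homo sapiens) for metabolic stability, read by LC-MS, using NADPH, with stated times of 5 min and 30 min, tested at 1 uM (a higher number here means faster removal of the compound, a lower number slower removal), compound 1 gives 14 mL.min-1.g-1. Compound 2 `O=C1c2ccccc2CN1c1cnc(NCc2c(F)ccc3c2CCO3)n2cnnc12` carries a fused lactam; in this assay compound 2 gives 13 mL.min-1.g-1. Compound 3 `O=C(Nc1cnc(NCc2c(F)ccc3c2CCO3)n2cnnc12)c1ccccc1` carries a benzamido group; in this assay compound 3 gives 10 mL.min-1.g-1. The steps are a 1.1-fold lower number from compound 1 to compound 2 (0.03 log units; within the scatter), a 1.4-fold lower number from compound 1 to compound 3 (0.15 log units; within the scatter) and a 1.3-fold lower number from compound 2 to compound 3 (0.11 log units; within the scatter); none lies beyond the scatter, so compound 3 stands at the lowest of the three numbers but cannot be separated from compound 1 or compound 2.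

Compound 4 `O=C1CC2(CC2)CN1c1cnc(NCc2c(F)ccc3c2CCO3)n2cnnc12` differs from compound 3 by the change (a group of 8 heavy atoms (6 carbon, 1 nitrogen, 1 oxygen; one three-membered non-aromatic ring of carbon only, one five-membered non-aromatic ring with 1 hetero atom) in place of a group of 9 heavy atoms (7 carbon, 1 nitrogen, 1 oxygen; one six-membered aromatic ring of carbon only), on an aromatic carbon). Among the compounds with values here, no measured step touches a group of this kind; the nearest comparison is the move from an aromatic amide to a cyclic lactam, seen in a 1.1-fold lower number from compound 1 to compound 2 (0.03 log units; within the scatter), which stayed within the scatter. Given that three different amide-type groups on this carbon gave numbers within the scatter of one another, no step beyond the scatter is expected here; the estimated step is a 1.1-fold lower number from compound 3 to compound 4 (0.05 log units; within the scatter). For compound 4 the expected value in this assay is 9 mL.min-1.g-1, within a range of 4 mL.min-1.g-1 to 20 mL.min-1.g-1.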

Compound 4, intrinsic clearance in microsomes: < 3 mL.min-1.g-1
Compound 4 ended at the assay's limit (the forecaster's own chance of this, stated with the estimate: 10%); middle value at least 3.0-fold (0.47 log units) from the limit.
By their numbers in this assay, from the lowest: compounds 3, 2 and 1 (each within the scatter of the next). At a limit, below all of these: compound 4.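

Compound 4 reads as a limit of the assay, not as a number: the limit of < 3 mL.min-1.g-1 in this assay, at which 1 of the 4 values shown sits. In this assay this aromatic carbon, para to a large group, proves able to shift the number: compound 1, compound 2 and compound 3 stayed within the scatter of one another, whereas the new group gives an at least 3.3-fold lower number from compound 3 to compound 4 (0.52 log units; beyond the scatter), an at least 4.3-fold lower number from compound 2 to compound 4 (0.63 log units; beyond the scatter) and an at least 4.6-fold lower number from compound 1 to compound 4 (0.66 log units; beyond the scatter). Compound 2 also carries no amide hydrogen, yet its step is beyond the scatter too, so among these four compounds the lower number goes with the loss of the six-membered aromatic ring of carbon only, and the absence of the amide hydrogen alone does not account for it.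

The group of compound 4 both lacks that aromatic ring and adds a three-membered ring of carbon only, and the compounds shown cannot assign the step to either feature. Also open, as far as these compounds go, is whether a plain five-membered lactam without the three-membered ring, or an amine or a carboxylic acid on this carbon, would stay with compound 4 or with the other three compounds.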